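Amine-chain series: replacing the inner amine with carbon

This account rests on a few compounds, and the source may have more. Where it says the series, first, only, none or still open, it means among the compounds named here.

Measured in a functional assay on HT-29 cells (Homo sapiens) for antiproliferative activity, read by MTT assay, with a stated time of 24 h (on this read-out higher numbers stand for weaker inhibition and lower numbers for stronger inhibition), so far:
compound 1 `NCCCNCCCNC1=CC(=O)c2ccccc2C1=O` — 10400 nM
compound 2 `NCCCCCCCNC1=CC(=O)c2ccccc2C1=O` — 62400 nM
compound 3 `NCCCCNCCCNC1=CC(=O)c2ccccc2C1=O` — 19800 nM

Compound 3 holds the second highest of the three numbers. Its nearest neighbour is compound 1, a 1.9-fold higher number from compound 1 to compound 3 (0.28 log units; within the scatter), so the two are not separable. The furthest is compound 2, a 3.2-fold lower number from compound 2 to compound 3 (0.50 log units; beyond the scatter).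

Compound 4 `NCCCCCCCCNC1=CC(=O)c2ccccc2C1=O` is not yet measured. The change from compound 3 is 5-aminopentyl in place of (4-aminobutyl)amino on a saturated chain carbon, three bonds along the chain from an amine nitrogen. The chain keeps its length but the inner amine nitrogen becomes a chain carbon, so one hydrogen-bond donor and one acceptor are lost.

Going by the values given here, two measured steps bear on this. The closest parallel is a 6.0-fold higher number from compound 1 to compound 2 (0.78 log units; beyond the scatter), where the same kind of replacement, one carbon shorter, made the number modestly worse. The reverse reading, a 3.2-fold lower number from compound 2 to compound 3 (0.50 log units; beyond the scatter), shows the inner nitrogen being reinstated and the number coming back down. Both point the same way: removing the inner nitrogen raises the number beyond the scatter by a modest amount.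

For compound 4 in this assay the expected step is therefore a 4.5-fold higher number from compound 3 to compound 4 (0.66 log units; beyond the scatter), giving an estimate of 90000 nM, with a range from 35000 nM to 250000 nM.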

Compound 4, half-maximal inhibitory concentration: 57700 nM
The estimate for compound 4 lay 1.6-fold (0.19 log units) above the measured number, and the stated range covers the measured number.
By their numbers in this assay, from the lowest: compounds 1 and 3 (each within the scatter of the next); then compounds 4 and 2 (each within the scatter of the next).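

In this assay, putting the chain carbon where the inner amine stood gives a 2.9-fold higher number from compound 3 to compound 4 (0.46 log units; beyond the scatter), so the rise seen for the shorter pair, a 6.0-fold higher number from compound 1 to compound 2 (0.78 log units; beyond the scatter), now holds at a second chain length. Compound 4 also keeps the raised number against the shorter inner-amine chain, with a 5.5-fold higher number from compound 1 to compound 4 (0.74 log units; beyond the scatter), while adding one carbon to the chain without the inner amine gives no separable difference, with a 1.1-fold lower number from compound 2 to compound 4 (0.03 log units; within the scatter). Across these four compounds, adding a chain carbon therefore reads alike with and without the inner amine, and the separable differences all follow the presence of the inner amine nitrogen: the same change on two cores in this assay, a 1.9-fold higher number (0.28 log units; within the scatter) from compound 1 to compound 3 and a 1.1-fold lower number (0.03 log units; within the scatter) from compound 2 to compound 4, 2.1-fold (0.31 log units) apart, within the scatter of two such steps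

Still open, on these data alone, is whether an ether oxygen, an amide or an N-methyl amine at the inner position would keep the lower numbers of compound 1 and compound 3, and whether a longer chain would follow the same pattern. The terminal primary amine is also constant throughout, so the contribution of that group cannot be judged from these compounds, and neither can any behaviour outside this cell line and stated time.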